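Iodo for bromo on the amino-bearing ring

A few compounds are considered here, and "the series" means these few. Any claim that something is new, unique, unknown or untested is made for them only; others in the source may bear on it.

Of the compounds shown here, three have been measured in an assay on cell membranes for binding affinity to sodium-dependent dopamine transporter (Rattus norvegicus); a higher number here means a weaker inhibitor, a lower number a stronger inhibitor. Compound 1 `CN(C)Cc1ccccc1Sc1ccc(Br)cc1CO` gives 950 nM, and compound 2 `CNCc1ccccc1Sc1ccc(I)cc1CO` gives 760 nM. Compound 3 `CNCc1ccccc1Sc1ccc(Br)cc1N` gives 171 nM, the lowest number of the three, and its gaps to compound 2 and to compound 1 both lie beyond the scatter. Compound 4 `CNCc1ccccc1Sc1ccc(I)cc1N` has not yet been measured in this assay; it differs from compound 3 only by iodo in place of bromo on an aromatic carbon. For the measured compounds named here, no pair of measured compounds differs by this change alone, so nothing measured here fixes its size. The step is expected to be a 1.1-fold lower number from compound 3 to compound 4 (0.03 log units; within the scatter), not beyond the scatter in either direction. Compound 4 is therefore estimated at 160 nM, with a range from 60 nM to 420 nM.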

Compound 4, inhibition constant: 818 nM
The estimate for compound 4 lay 5.1-fold (0.71 log units) below the measured number; measured number outside the range, above it.
By their numbers in this assay, from the lowest: compound 3; then compounds 2, 4 and 1 (each within the scatter of the next).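

On the ring bearing the amino group, the halogen meta to that amino group and para to a large group is not interchangeable in this assay: iodo in place of bromo gives a 4.8-fold higher number from compound 3 to compound 4 (0.68 log units; beyond the scatter). With iodo held in place, amino in place of hydroxymethyl gives a 1.1-fold higher number from compound 2 to compound 4 (0.03 log units; within the scatter), so these two groups are not separated here. Nothing available explains the bromo to iodo step.

The compounds shown leave open whether this halogen step also holds with hydroxymethyl in place of amino. They also leave open how chloro or a methyl group would compare at this position.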